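The source may report more compounds than this note shows. Statements on the series, on what has been measured and on what is new or still open speak of the compounds shown alone.

Measured so far in an ADME assay on Caco-2 cells (Homo sapiens) for permeability, in the apical to basolateral direction, at pH 7.4; a lower number here means that the compound crosses the layer more slowly, a higher number that the compound crosses the layer faster:
- compound 1 `Cc1ccc2[nH]c(C(=O)N[C@H]3CN(S(=O)(=O)c4ccccc4)C[C@@H]3C(=O)NC[C@H]3CCCN3C)cc2c1`: 0.08 10^-6 cm/s
- compound 2 `Cc1ccc2[nH]c(C(=O)N[C@H]3CN(S(=O)(=O)c4ccccc4)C[C@@H]3C(=O)N[C@H]3CCCN(C)C3)cc2c1`: 0.3 10^-6 cm/s
- compound 3 `Cc1ccc2[nH]c(C(=O)N[C@H]3CN(S(=O)(=O)c4ccccc4)C[C@@H]3C(=O)N[C@H]3CCCNC3)cc2c1`: 0.04 10^-6 cm/s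

In this assay, compound 3 cannot be told apart from compound 1, since a 2.0-fold lower number from compound 1 to compound 3 (0.30 log units; within the scatter) stays within the scatter. Compound 2 stands clearly apart from it, as a 7.5-fold lower number from compound 2 to compound 3 (0.88 log units; beyond the scatter) shows. Compound 3 therefore belongs to the slow-crossing end of this small set.

The next compound, compound 4 `O=C(N[C@H]1CN(S(=O)(=O)c2ccccc2)C[C@@H]1C(=O)N[C@H]1CCCNC1)c1cc(C2CC2)n[nH]1`, keeps the piperidin-3-yl group of compound 3 on the amide-type nitrogen. The change lies elsewhere, on a carbonyl carbon: 3-cyclopropyl-1H-pyrazol-5-yl in place of 5-methyl-1H-indol-2-yl (3-cyclopropyl-1H-pyrazol-5-yl in place of 5-methyl-1H-indol-2-yl on a carbonyl carbon).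

Among the compounds with values here, none of the measured steps touches this place. The steps of a 3.8-fold higher number from compound 1 to compound 2 (0.57 log units; beyond the scatter) and a 7.5-fold lower number from compound 2 to compound 3 (0.88 log units; beyond the scatter) are modest, but both come from changes at the other end of the molecule, and they show only how far this series can move. With no direct evidence on this swap, neither direction can be favoured, so no step beyond the scatter is expected. The expected change is a 1.3-fold higher number from compound 3 to compound 4 (0.10 log units; within the scatter).

Compound 4 is estimated at 0.05 10^-6 cm/s, with an expected range of 0.02 10^-6 cm/s to 0.15 10^-6 cm/s.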

Compound 4, apparent permeability: 0.39 10^-6 cm/s
Estimate against measurement, compound 4: 7.8-fold (0.89 log units) below; the measured number lies above the stated range.
By their numbers in this assay, from the lowest: compounds 3 and 1 (each within the scatter of the next); then compounds 2 and 4 (each within the scatter of the next).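

On the carbonyl carbon, with the piperidin-3-yl group held fixed, 3-cyclopropyl-1H-pyrazol-5-yl in place of 5-methyl-1H-indol-2-yl gives a 9.8-fold higher number from compound 3 to compound 4 (0.99 log units; beyond the scatter) in this assay, so this end of the molecule can also move the number. Within the data shown here, until now, the only steps beyond the scatter came from the other end of the molecule, such as a 7.5-fold lower number from compound 2 to compound 3 (0.88 log units; beyond the scatter) on the amine nitrogen. The swap alters several things at once, with fewer heavy atoms entering than leaving and a hydrogen-bond acceptor entering where none leaves, and no available measurement separates these differences or accounts for the rise.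

From the compounds shown here alone, the 3-cyclopropyl-1H-pyrazol-5-yl group appears here only with piperidin-3-yl on the amide-type nitrogen, so it remains open whether a similar step would occur with the 1-methylpiperidin-3-yl group of compound 2 or the (1-methylpyrrolidin-2-yl)methyl group of compound 1. Going by these compounds, it is also open how much of the step depends on the cyclopropyl ring, which a methyl group or a hydrogen in its place on the same pyrazole would begin to test.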